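Stereocentre inversion in a chloro amino series

This account rests on a few compounds, and the source may have more. Where it says the series, first, only, none or still open, it means among the compounds named here.

Measured compounds:
- compound 1 `CC(C)N(c1nc(Cl)nc(N[C@@H](C)c2ccccc2)n1)C(C)C`: 372 nM
- compound 2 `CCCN(CC)c1nc(Cl)nc(N[C@@H](C)c2ccccc2)n1`: 479 nM
- compound 3 `CC[C@@H](C)Nc1nc(Cl)nc(N[C@@H](C)c2ccccc2)n1`: 9770 nM

In an ADME assay on the whole organism for inhibition, with Oryza sativa as the target, with a stated time of 4 days (on this read-out higher numbers stand for weaker inhibition and lower numbers for stronger inhibition), compound 1 gives 372 nM, the lowest number of the three, although its gap to compound 2 lies within the scatter: a 1.3-fold higher number from compound 1 to compound 2 (0.11 log units; within the scatter). Compound 3 is clearly separated from it: a 26-fold higher number from compound 1 to compound 3 (1.42 log units; beyond the scatter). The other step to compound 3 is similar: a 20-fold higher number from compound 2 to compound 3 (1.31 log units; beyond the scatter).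

The next compound is compound 4 `CC(C)N(c1nc(Cl)nc(N[C@H](C)c2ccccc2)n1)C(C)C`, which relates to compound 1 as follows: the two compounds have the same atoms and bonds and differ only in configuration as drawn: 1 of 1 stereo elements differ; a stereocentre at a saturated chain carbon is drawn S in compound 1 and R in compound 4.

For the measured compounds named here, no measured step changes configuration alone, since all three replace the amino group. Going by the values given here, they show only that a single change can leave this assay unmoved or shift it widely, so the size and direction of this step remain open, and the range must stay wide. A moderate move towards weaker inhibition is expected, given that compound 1 stands at the low end of the numbers.

The expected step is a 2.7-fold higher number from compound 1 to compound 4 (0.43 log units; beyond the scatter).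

For compound 4 the estimated value is 1000 nM, with an expected range of 250 nM to 6000 nM.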

Compound 4, half-maximal inhibitory concentration: 1620 nM
The estimate for compound 4 lay 1.6-fold (0.21 log units) below the measured number, within the range that was stated.
By their numbers in this assay, from the lowest: compounds 1 and 2 (each within the scatter of the next); then compound 4; then compound 3.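

Configuration at the saturated chain carbon matters in this series, since the earlier steps all replaced the amino group and none isolated this stereocentre. With diisopropylamino held constant, going from the S to the R form as drawn gives a 4.4-fold higher number from compound 1 to compound 4 (0.64 log units; beyond the scatter) in this assay. The shift can be assigned to the stereocentre alone because nothing else changes: the fact that compounds 1 and 4 differ only in the configuration as drawn

As far as these compounds go, the preference for the S form as drawn rests on this single pair, so it remains unknown whether the same inversion moves the number in the same direction or by a similar size with ethyl(propyl)amino or (sec-butyl)amino as the partner group. The compounds shown also leave open how the inversion behaves with a cyclic amine such as morpholine in place of diisopropylamino.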